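A few compounds are considered here, and "the series" means these few. Any claim that something is new, unique, unknown or untested is made for them only; others in the source may bear on it.

Measured compounds in a functional assay on cells (Platelet, Homo sapiens) for inhibition; on this read-out higher numbers stand for weaker inhibition and lower numbers for stronger inhibition:
compound 1 `O=C(O)c1ccc(-c2nn(Cc3ccccc3)c3ccccc23)cc1` – > 10000 nM (a limit of the assay, not a number)
compound 2 `COC(=O)c1ccc(-c2nn(Cc3ccccc3)c3ccccc23)cc1` – 560 nM
compound 3 `CCNC(=O)c1ccc(-c2nn(Cc3ccccc3)c3ccccc23)cc1` – 5640 nM

Compound 3 holds the highest of the two numbers in this assay; its nearest neighbour is compound 2, separated by the step of a 10-fold higher number from compound 2 to compound 3 (1.00 log units; beyond the scatter). Compound 1 sits only at a limit, (the limit of > 10000 nM in this assay, at which 1 of the 3 values shown sits), so its distance to compound 3 is bounded but not fixed: an at least 1.7-fold lower number from compound 1 to compound 3 (0.24 log units; that floor lies within the scatter).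

The next compound, compound 4 `CCOC(=O)/C=C/c1ccc(-c2nn(Cc3ccccc3)c3ccccc23)cc1`, changes compound 3 at one place: 2-(ethoxycarbonyl)ethenyl in place of ethylcarbamoyl on an aromatic carbon. The ethylcarbamoyl group goes, and an ester-bearing chain of two extra carbons comes in.

Among the compounds with values here, two measured steps bear on this. The ester-to-amide change a 10-fold higher number from compound 2 to compound 3 (1.00 log units; beyond the scatter) raised the number by a modest amount, and the acid-to-ester change an at least 17-fold lower number from compound 1 to compound 2 (1.25 log units; beyond the scatter) lowered it by a large amount. Both point the same way: an ester group at this position gives a lower number than an amide or acid. Compound 4 carries an ester, though on a longer arm, so the step is expected to run downward and beyond the scatter, roughly a 3.8-fold lower number from compound 3 to compound 4 (0.58 log units; beyond the scatter). For compound 4 the estimate is therefore 1500 nM, expected to lie between 300 nM and 8000 nM.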

Compound 4, half-maximal inhibitory concentration: > 10000 nM
Compound 4: no number, only a limit; the forecaster's own chance of this, stated with the estimate: 10%; middle value at least 6.6-fold (0.82 log units) away from the limit.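

In this assay compound 4 gives > 10000 nM, which is a limit of the assay and not a number, and it now shares that limit with the acid: the limit of > 10000 nM in this assay, at which 2 of the 4 values shown sit.

An ester at this place, para to a large group, is not enough by itself: the exchange of methoxycarbonyl for 2-(ethoxycarbonyl)ethenyl gives an at least 17-fold higher number from compound 2 to compound 4 (1.25 log units; beyond the scatter), so the gain seen for the methyl ester does not carry over to this longer ester-bearing arm. Against the ethylcarbamoyl group, the new arm shows an at least 1.7-fold higher number from compound 3 to compound 4 (0.24 log units; that floor lies within the scatter), so these two are not separated beyond the scatter by what is printed, and the step from the acid to compound 4 cannot be read, with a limit at both ends.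

The change to compound 4 brings in the ethenyl link, the longer arm and an ethyl in place of a methyl on the ester oxygen together, and the compounds shown do not tell which of these goes with the loss. An ethyl ester without the ethenyl link, a saturated chain in its place, or an amine at this position would each bear on that question.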